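The compounds below may be only part of what the source reports. "The series", "measured", "known", "first", "only" and "open" are said of these compounds alone.

Three compounds share one core and were tested in a functional assay on K562 cells (Homo sapiens) for antiproliferative activity, read by sulforhodamine B assay, with a stated time of 72 h; on this read-out lower numbers stand for stronger inhibition and higher numbers for weaker inhibition. Compound 1 `CCN1C(=O)CS/C1=N/Nc1nncc2ccccc12` gives 76 nM, compound 2 `O=S(=O)(Nc1ncccn1)c1ccc(Nc2nncc3ccccc23)cc1` gives 43 nM, and compound 3 `Fc1ccc(Nc2nncc3ccccc23)cc1` gives 6.7 nM. Compound 2 and compound 1 lie within the usual scatter of each other, so their numbers cannot be told apart, while the number of compound 3 sits beyond that scatter on the lower side.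

Compound 4 `O=S(=O)(Nc1ccccn1)c1ccc(Nc2nncc3ccccc23)cc1` differs from compound 2 in one place: pyridin-2-yl in place of pyrimidin-2-yl on a sulfonamide nitrogen. This swap removes one ring nitrogen and nothing else. Within the data shown here, no measured pair shows this swap, so nothing on file constrains it; the expected step is none beyond the scatter, a 1.1-fold lower number from compound 2 to compound 4 (0.03 log units; within the scatter). Compound 4 is therefore estimated at 40 nM in this assay, with a range from 15 nM to 110 nM.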

Compound 4, half-maximal inhibitory concentration: 34 nM
Compound 4: middle estimate off by 1.2-fold (0.07 log units), on the high side; the measured number falls inside the stated range.
By their numbers in this assay, from the lowest: compound 3; then compounds 4, 2 and 1 (each within the scatter of the next, the first and the last beyond it).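

In this assay, among these compounds, this is the first pair that isolates a single change, and it concerns the ring on the sulfonamide nitrogen. Going from pyrimidin-2-yl to pyridin-2-yl removes one ring nitrogen, yet the two numbers cannot be told apart (a 1.3-fold lower number from compound 2 to compound 4 (0.10 log units; within the scatter)), so at this position that nitrogen makes no visible difference to antiproliferative activity. Nothing available explains this result. As far as these compounds go, it remains open whether the other ring nitrogen matters, which a plain phenyl ring could test. From the compounds shown here alone, it is also open whether a non-aromatic group, such as a methyl group or a longer chain carrying an amine, would shift the number.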